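The source may report more compounds than this note shows. Statements on the series, on what has been measured and on what is new or still open speak of the compounds shown alone.

Working notes on the series.

Compound 1 `CCCS(=O)(=O)Nc1ccc(F)c(C(=O)c2n[nH]c3ncc(-c4ccccc4OC)cc23)c1F` and compound 2 `CCCS(=O)(=O)Nc1ccc(F)c(C(=O)c2n[nH]c3ncc(-c4ccccc4N)cc23)c1F` share one core and differ only in the group on the outer phenyl ring. In an assay for binding affinity to dual specificity mitogen-activated protein kinase kinase 4 (Homo sapiens), read by KINOMEscan, tested at 100 nM (on this read-out lower numbers stand for a stronger effect and higher numbers for a weaker effect at the one concentration tested), compound 1 gives 1.9%, and compound 2 gives 23%. Among the measured compounds shown here, compound 2 thus stands highest of the two numbers measured so far, and the single step between them, a number 21.1 percentage points higher from compound 1 to compound 2 (beyond the scatter), lies beyond the scatter.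

Compound 3 `CCCS(=O)(=O)Nc1ccc(F)c(C(=O)c2n[nH]c3ncc(-c4ccc(F)cc4C)cc23)c1F` is not yet measured. It differs from compound 2 as follows: 4-fluoro-2-methylphenyl in place of 2-aminophenyl on an aromatic carbon. The entering 4-fluoro-2-methylphenyl carries no hydrogen-bond donor and no acceptor, so it resembles compound 1 more than compound 2 in that respect. For the measured compounds named here, the only step that bears on this change is a number 21.1 percentage points higher from compound 1 to compound 2 (beyond the scatter), which shows that removing the amino and returning to a group without a donor moves the read-out well downward. A step of that order is therefore expected in this assay, in the downward direction, written as a number 17 percentage points lower from compound 2 to compound 3 (beyond the scatter). Compound 3 is accordingly estimated at 6% in this assay, with a range from 0.5% to 30%.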

Compound 3, a percentage reported as activity, at one concentration (the size of the read-out at that concentration, not a potency): 14%
Compound 3: the middle estimate sits 8 percentage points below what was measured; the measured number falls inside the stated range.
By their numbers in this assay, from the lowest: compound 1; then compounds 3 and 2 (each within the scatter of the next).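

Replacing 2-aminophenyl with 4-fluoro-2-methylphenyl gives a number 9 percentage points lower from compound 2 to compound 3 (within the scatter) in this assay and so does not separate these two groups, even though 2-aminophenyl has 1 hydrogen-bond donor and 4-fluoro-2-methylphenyl has 0 hydrogen-bond donors. Replacing 2-methoxyphenyl with 4-fluoro-2-methylphenyl gives a number 12.1 percentage points higher from compound 1 to compound 3 (beyond the scatter) and shows that the low number of compound 1 is not reproduced by every group without an amino substituent at this position, so the earlier step from methoxy to amino cannot be read as a simple effect of that donor. Nothing on hand explains the differences among these outer aryl groups.

The compounds shown leave open how much of the result for compound 3 belongs to the fluorine and how much to the methyl, since the two enter together on the same ring. Also open, on these data alone, is how the read-out at this position would respond to a 2-hydroxyphenyl or 2-ethoxyphenyl group, or to a pyridyl ring in place of the outer phenyl.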